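Replacing an ethoxy group on a thiocarbonyl carbon

The source may report more compounds than this note shows. Statements on the series, on what has been measured and on what is new or still open speak of the compounds shown alone.

Of the compounds shown here, two have been measured in an assay on HEK293 cells for inhibition of protein deacetylase HDAC6 (Homo sapiens); on this read-out higher numbers stand for weaker inhibition and lower numbers for stronger inhibition. Compound 1, `CCSC(=S)SCC(=O)c1ccc(C(=O)N[C@@H](C)c2ccccc2)s1`, gives 135 nM in this assay. Compound 2, `CCOC(=S)SCC(=O)c1ccc(OC)cc1`, gives 448 nM in this assay, the higher of the two numbers and therefore the weaker inhibition; the two compounds differ in several places at once, so the gap between them is not tied to a single change.

Compound 3, `COc1ccc(C(=O)CSC(=S)SCCNC(C)=O)cc1`, has not yet been measured. It differs from compound 2 in one place only: (2-acetamidoethyl)sulfanyl in place of ethoxy on a thiocarbonyl carbon. Among the measured compounds shown here, no measured pair shows this exact change, so the step it produces in this assay is open. Given that compound 1, which also carries a sulfur rather than an oxygen on that thiocarbonyl carbon, gives 135 nM, a modest move toward stronger inhibition is expected, though a step no larger than the usual scatter is equally plausible. Compound 3 is therefore estimated to give 300 nM in this assay, within a range of 120 nM to 750 nM, which would be a step of a 1.5-fold lower number from compound 2 to compound 3 (0.17 log units; within the scatter).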

Compound 3, half-maximal inhibitory concentration: 1640 nM
Compound 3: the middle estimate sits 5.5-fold (0.74 log units) below what was measured; the whole stated range lies below it.
By their numbers in this assay, from the lowest: compound 1; then compound 2; then compound 3.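

In this assay, the change to (2-acetamidoethyl)sulfanyl in place of ethoxy on a thiocarbonyl carbon gives a 3.7-fold higher number from compound 2 to compound 3 (0.56 log units; beyond the scatter), which means weaker inhibition and shows that what this position carries can matter beyond the usual scatter. This one step swaps more than one feature at once: the group entering has 7 heavy atoms against 3 in the group leaving, sulfur replaces oxygen as the atom bonded to the thiocarbonyl carbon, and an amide with a hydrogen-bond donor is added at the end of the chain. Nothing available here explains the weaker inhibition or assigns it to any one of those features.

The compounds shown leave open whether the step comes from the sulfur link, the added length or the acetamido end, and a methylsulfanyl group on the core of compound 2 would begin to separate these. As far as these compounds go, it also remains open how this position would respond to a chain ending in a free amine or a carboxylic acid, or to a longer chain without the amide.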